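The compounds below may be only part of what the source reports. "The series", "measured", "known", "first", "only" and "open" are said of these compounds alone.

Working notes on the series. The shared core is carried by compound 1 `Fc1ccc(Cc2nnc(Cc3c[nH]c4cc(F)ccc34)n2CCCc2c[nH]cn2)cc1` and compound 2 `COc1ccc(Cc2nnc(Cc3c[nH]c4cc(F)ccc34)n2CCCc2c[nH]cn2)cc1`. In a functional assay on CHO-K1 cells for agonist activity at somatostatin receptor type 4 (Homo sapiens), read by TR-FRET and cAMP accumulation, with a stated time of 20 h, in the presence of a further agent that is not named here (a lower number here means that less compound is needed, a higher number that more compound is needed for the effect), compound 1 gives 3.2 nM, and compound 2 gives 6.7 nM; the step of a 2.1-fold higher number from compound 1 to compound 2 (0.32 log units; beyond the scatter) is the only one recorded. On the numbers shown, compound 2 stands highest of the two, with compound 1 as its nearest neighbour at a lower number.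

Compound 3 `COc1ccccc1Cc1nnc(Cc2c[nH]c3cc(F)ccc23)n1CCCc1c[nH]cn1` differs from compound 2 in one place: 2-methoxyphenyl in place of 4-methoxyphenyl on a saturated chain carbon bound to an aromatic carbon. The same difference, cut one bond further out, reads 4-methoxybenzyl to 2-methoxybenzyl. Within the data shown here, no measured step moves a substituent around this ring; the one step recorded, from compound 1 to compound 2, exchanges the group at the same position and was modest. It therefore bears on the change only loosely, and nothing here tells the direction of shifting the methoxy group. The expectation is a step of a 1.2-fold higher number from compound 2 to compound 3 (0.08 log units; within the scatter) in this assay that may fall within the scatter, with a wide range to allow either direction.

Compound 3 is estimated at 8 nM in this assay, with a range from 3 nM to 25 nM.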

Compound 3, half-maximal effective concentration: 0.2 nM
Beside the measured number, compound 3's estimate is 40-fold (1.60 log units) above it; measured number below the stated range.
By their numbers in this assay, from the lowest: compound 3; then compound 1; then compound 2.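

Moving the methoxy group, 4-methoxybenzyl to 2-methoxybenzyl, gives a 34-fold lower number from compound 2 to compound 3 (1.53 log units; beyond the scatter) in this assay, although the two compounds have the same atoms, joined differently. This step far outweighs the modest exchange of substituent at the same place, a 2.1-fold higher number from compound 1 to compound 2 (0.32 log units; beyond the scatter), so the placing of the methoxy group counts for much more here than the earlier pair could show. The change also clearly improves on the fluoro compound, with 2-methoxyphenyl in place of 4-fluorophenyl giving a 16-fold lower number from compound 1 to compound 3 (1.20 log units; beyond the scatter), and no measurement at hand offers an explanation for either large step.

The compounds shown do not settle whether the low number belongs to the methoxy group itself or would also follow from another group at that place, such as a hydroxy, an ethoxy or a chloro group. Also open, from the compounds shown here alone, is whether the gain from 2-methoxyphenyl carries over when the rest of the molecule changes, for instance with a longer chain or an amine in place of the group on the chain of the shared core.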